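This account rests on a few compounds, and the source may have more. Where it says the series, first, only, none or still open, it means among the compounds named here.

Three compounds sharing one five-membered aromatic core carrying a methoxycarbonyl group have been tested in a functional assay on NCI-H226 cells (Homo sapiens) for inhibition, read by MTT assay, with a stated time of 72 h; a lower number here means a stronger inhibitor of growth, a higher number a weaker inhibitor of growth. Compound 1 `COC(=O)c1nc(C)n(-c2cccc(Br)c2)n1` gives 7350 nM. Compound 2 `COC(=O)c1nc(C(C)C)n(-c2ccc(F)cc2)n1` gives 6170 nM, and compound 3 `CCCCc1nc(C(=O)OC)nn1-c1ccc(F)cc1` gives 6400 nM. These three numbers sit close together: the nearest to compound 3 is compound 2, the furthest is compound 1, and both gaps fall within the usual scatter, so none of the three can be called stronger or weaker than another.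

Compound 4 `COC(=O)c1nc(C2CCCCC2)n(-c2ccc(F)cc2)n1` differs from compound 3 in one place: cyclohexyl in place of butyl on an aromatic carbon. Within the data shown here, the only measured step at that same position is a 1.0-fold higher number from compound 2 to compound 3 (0.02 log units; within the scatter), a change from one alkyl group to another that left the number essentially where it was. Among the measured compounds shown here, the move to a six-membered ring of carbon is a further change of the same kind, and with only this one step as guidance, a similarly small step is expected in this assay. Compound 4 is therefore expected to give about 6400 nM, within a range of 3000 nM to 14000 nM, which corresponds to an estimated step of no change at the digits printed from compound 3 to compound 4 (within the scatter).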

Compound 4, concentration for 50% growth inhibition: 6260 nM
Compound 4: the middle estimate sits 1.0-fold (0.01 log units) above what was measured, and the stated range covers the measured number.
By their numbers in this assay, from the lowest: compounds 2, 4, 3 and 1 (each within the scatter of the next).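

In this assay, cyclohexyl in place of butyl gives a 1.0-fold lower number from compound 3 to compound 4 (0.01 log units; within the scatter) and cyclohexyl in place of isopropyl gives a 1.0-fold higher number from compound 2 to compound 4 (0.01 log units; within the scatter) on the same aromatic carbon. The earlier compounds shown here carried only open chains at this position, whereas compound 4 brings a six-membered ring of carbon, and its number still cannot be told apart from those of the straight butyl chain and the branched isopropyl group. No information is available to explain why these three groups give such similar numbers.

Going by these compounds, all three groups contain carbon only, so it remains open whether an amine, a carboxylic acid or a phenyl ring at this position would shift the number beyond the scatter. A much longer chain or a smaller group such as methyl on the same core is equally unresolved.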